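The compounds below may be only part of what the source reports. "The series", "measured", "known", "first", "only" and "open" are said of these compounds alone.

Measured compounds:
Compound 1, `ClCc1cccc(Cn2cnc3ncnc(Cl)c32)c1`: 210 nM
Compound 2, `ClCc1ccccc1Cn1cnc2ncnc(Cl)c21`: 1990 nM
Compound 3, `ClCc1cccc(Cn2cnc3nc(Cl)nc(Cl)c32)c1`: 220 nM

All three were tested in a functional assay on T47D cells (Homo sapiens) for cytotoxicity, read by sulforhodamine B assay, with a stated time of 48 h; on this read-out lower numbers stand for stronger inhibition of growth and higher numbers for weaker inhibition of growth. Compound 1 and compound 2 are built from the same atoms joined differently; the difference between the two cores is not broken down here. Their values show that compound 2 gives the highest number of the three, so it inhibits growth less strongly than compound 1 or compound 3 in this assay.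

Compound 3 differs from compound 1 by chloro in place of hydrogen on an aromatic carbon. This change made a step of a 1.0-fold higher number from compound 1 to compound 3 (0.02 log units; within the scatter), so the added chloro left the growth inhibition essentially unchanged.

Compound 4, `ClCc1ccccc1Cn1cnc2nc(Cl)nc(Cl)c21`, has not yet been measured. Among the measured compounds shown here, it differs from compound 2 by chloro in place of hydrogen on an aromatic carbon, which is the same change as the one from compound 1 to compound 3, at a place described in the same words. On the core of compound 1 this change made no real difference, so a step of a 1.0-fold higher number from compound 2 to compound 4 (0.00 log units; within the scatter) is expected for compound 4 as well, resting on the step of a 1.0-fold higher number from compound 1 to compound 3 (0.02 log units; within the scatter). Compound 4 is therefore estimated to give 2000 nM in this assay, likely between 900 nM and 4500 nM.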

Compound 4, concentration for 50% growth inhibition: 580 nM
Compound 4: the middle estimate sits 3.4-fold (0.54 log units) above what was measured; measured number outside the range, below it.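

In this assay, chloro in place of hydrogen on the aromatic carbon between two ring nitrogen atoms gave a 3.4-fold lower number from compound 2 to compound 4 (0.54 log units; beyond the scatter), so on the core of compound 2 the change lowered the number, and growth inhibition became stronger. The same change therefore does not have one fixed size across these two cores, and a step seen on one core is a poor guide to the step on the other: the same change on two cores in this assay, a 1.0-fold higher number (0.02 log units; within the scatter) from compound 1 to compound 3 and a 3.4-fold lower number (0.54 log units; beyond the scatter) from compound 2 to compound 4, 3.6-fold (0.56 log units) apart, beyond the scatter of two such steps

Among the compounds shown here, this comparison rests on only two pairs of compounds, so it shows that the core matters here but does not show why, nor does it set a rule for any further core.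

As far as these compounds go, it remains open how other groups on that same carbon, such as an amine, a methoxy group or a longer chain, would behave on either core. From the compounds shown here alone, it also remains open whether any such group would again give steps of different size on the two cores.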